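From trifluoromethoxy to methoxy on a growth inhibitor

This account rests on a few compounds, and the source may have more. Where it says the series, first, only, none or still open, it means among the compounds named here.

Compound 3 `Oc1cccc2[nH]c(-c3ccc(-c4ccc(-c5ccc(OC(F)(F)F)cc5)cc4)cc3)nc12` gives 2210 nM in a functional assay on MCF7 cells (Homo sapiens) for inhibition, read by sulforhodamine B assay (a higher number here means a weaker inhibitor of growth, a lower number a stronger inhibitor of growth), and stands level, within the scatter, with compound 2 `Oc1cccc2[nH]c(-c3ccc(-c4ccc(-c5ccc(F)cc5)cc4)cc3)nc12` at 3010 nM on the same read-out. Compound 1 `COc1ccc(-c2ccc(-c3ccc(-c4nc5ccccc5[nH]4)cc3)cc2)cc1` gives 33300 nM and is clearly the weaker inhibitor of growth when set against compound 3.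

The next structure is compound 4 `COc1ccc(-c2ccc(-c3ccc(-c4nc5c(O)cccc5[nH]4)cc3)cc2)cc1` and the change is methyl in place of trifluoromethyl on an oxygen on an aromatic ring with methyl in place of trifluoromethyl on an oxygen on an aromatic ring, so 4-(trifluoromethoxy)phenyl becomes 4-methoxyphenyl.

The closest measured change is a 1.4-fold lower number from compound 2 to compound 3 (0.13 log units; within the scatter) and it puts trifluoromethoxy in place of fluoro on an aromatic carbon. That exchange stayed within the scatter. Among the measured compounds shown here, compound 1 at 33300 nM also carries 4-methoxyphenyl, but its core differs from that of compound 4, so it offers no clean step.

The expected change is a 1.6-fold higher number from compound 3 to compound 4 (0.20 log units; within the scatter) and nothing beyond the scatter is expected. For compound 4 the estimated value is 3500 nM with an expected range from 1300 nM to 10000 nM in this assay once it is measured.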

Compound 4, concentration for 50% growth inhibition: 3110 nM
Compound 4: middle estimate off by 1.1-fold (0.05 log units), on the high side; the range from low to high includes it.
By their numbers in this assay, from the lowest: compounds 3, 2 and 4 (each within the scatter of the next); then compound 1.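

In this assay the exchange of trifluoromethyl for methyl on the oxygen gives a 1.4-fold higher number from compound 3 to compound 4 (0.15 log units; within the scatter) and methoxy against fluoro gives a 1.0-fold higher number from compound 2 to compound 4 (0.01 log units; within the scatter), so all three groups at this position read alike. Among the compounds shown here, the one large step lies elsewhere: with 4-methoxyphenyl kept in place, hydroxy in place of hydrogen on an aromatic carbon gives an 11-fold lower number from compound 1 to compound 4 (1.03 log units; beyond the scatter), so here the hydroxy on the core changes the reading far more than the group at the far end does. Nothing on hand explains why these end groups read alike or why the hydroxy step is so large.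

Going by these compounds, what an amine, a carboxylic acid or a longer chain would do in place of the methoxy stays open. So does whether the hydroxy step would be as large with fluoro or trifluoromethoxy at the far end.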